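Replacing the 2-hydroxypropyl group of compound 3

A few compounds are considered here, and "the series" means these few. Any claim that something is new, unique, unknown or untested is made for them only; others in the source may bear on it.

Of the compounds shown here, three sharing one core have been measured in a functional assay on HeLa cells (Homo sapiens) for cytotoxicity, read by MTT assay; a higher number here means a weaker inhibitor, a lower number a stronger inhibitor. Compound 1 `CC(C)=CC[C@@H](OC(=O)c1ccco1)C1=CC(=O)c2c(O)ccc(O)c2C1=O` gives 80300 nM, and compound 2 `CCCC(O)CC(=O)O[C@H](CC=C(C)C)C1=CC(=O)c2c(O)ccc(O)c2C1=O` gives 59300 nM. Compound 3 `CC(C)=CC[C@@H](OC[C@@H](C)O)C1=CC(=O)c2c(O)ccc(O)c2C1=O` gives 22500 nM, the lowest number of the three.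

The next compound is compound 4 `CCCCC(O)CC(=O)O[C@H](CC=C(C)C)C1=CC(=O)c2c(O)ccc(O)c2C1=O`, in which (2-hydroxyhexyl)carbonyl stands in place of 2-hydroxypropyl on an oxygen on a saturated carbon: (2-hydroxyhexyl)carbonyl in place of 2-hydroxypropyl on an oxygen on a saturated carbon. For the measured compounds named here, two measured steps bear most directly on this change, and both end at compound 3 with a carbonyl-bearing group leaving that oxygen: a 3.6-fold lower number from compound 1 to compound 3 (0.55 log units; beyond the scatter) and a 2.6-fold lower number from compound 2 to compound 3 (0.42 log units; beyond the scatter). Both are modest. Compound 2 is the closer guide, as it carries (2-hydroxypentyl)carbonyl on that oxygen. The remaining step, a 1.4-fold lower number from compound 1 to compound 2 (0.13 log units; within the scatter), lies within the scatter, so the two carbonyl-bearing groups measured so far cannot be told apart in this assay. Going by the values given here, no measurement yet covers the 2-hydroxyhexyl chain itself.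

Read in reverse, a 2.6-fold lower number from compound 2 to compound 3 (0.42 log units; beyond the scatter) points to a modest rise in the number for the new compound. The expected change is a 2.4-fold higher number from compound 3 to compound 4 (0.39 log units; beyond the scatter). Compound 4 is estimated at 55000 nM, with an expected range from 27000 nM to 110000 nM.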

Compound 4, half-maximal inhibitory concentration: 72200 nM
Compound 4: middle estimate off by 1.3-fold (0.12 log units), on the low side; low and high end bracket the measured number.
By their numbers in this assay, from the lowest: compound 3; then compounds 2, 4 and 1 (each within the scatter of the next).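

For the compounds shown here, putting (2-hydroxyhexyl)carbonyl on this oxygen in place of 2-hydroxypropyl gives, in this assay, a 3.2-fold higher number from compound 3 to compound 4 (0.51 log units; beyond the scatter) and so measures this exchange directly for the first time, leaving compound 3 with the lowest number of the four. Adding one methyl to the end of the chain cannot be told apart, with a 1.2-fold higher number from compound 2 to compound 4 (0.09 log units; within the scatter) lying within the scatter, and the same holds for 2-hydroxyhexyl in place of furan-2-yl on the carbonyl carbon, with a 1.1-fold lower number from compound 1 to compound 4 (0.05 log units; within the scatter) also within the scatter, so compounds 1, 2 and 4 stand together whether the group on that carbonyl carbon is a ring or a chain. Among the groups shown on this oxygen, only the 2-hydroxypropyl of compound 3, which carries no carbonyl, stands apart from the three carbonyl-bearing groups, and nothing at hand says why this is so.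

As far as these compounds go, it remains open whether a 2-hydroxyhexyl chain joined directly to this oxygen, without the carbonyl, would keep the number near that of compound 3. Also open, from the compounds shown here alone, is whether an amine or a carboxylic acid in place of the chain's hydroxyl would shift the number at all.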